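The source may hold more compounds than are shown below. What is called first, only, known or untested is meant among the compounds shown, and "the series" means these compounds.

Of the compounds shown here, three built on one shared core have been tested in a functional assay on U-251 cells (Homo sapiens) for antiproliferative activity, read by MTT assay, with a stated time of 72 h; a higher number here means a weaker inhibitor, a lower number a stronger inhibitor. Compound 1 `O=C(Nc1ccc(Cl)c(-c2nnc3c(Cl)cccn23)c1)c1ccccn1` carries a pyridin-2-yl group on the carbonyl carbon of its amide, and in this assay compound 1 gives 79000 nM. Compound 2 `O=C(Nc1ccc(Cl)c(-c2nnc3c(Cl)cccn23)c1)c1cccnc1` differs only in bearing a pyridin-3-yl group at that carbon. For compound 2 the assay reports no number but only a limit, > 100000 nM. The step of an at least 1.2-fold higher number from compound 1 to compound 2 (0.10 log units; that floor lies within the scatter) can therefore be given only as a floor. Compound 3 `O=C(Nc1ccc(Cl)c(-c2nnc3c(Cl)cccn23)c1)c1ccc(C(F)(F)F)cc1F` carries a phenyl ring with fluorine and a trifluoromethyl group at the same carbon. For compound 3 the assay likewise reports only a limit, > 100000 nM. Compound 2 thus stands at the edge of what the assay can resolve, a position shared by two of the three results (the limit of > 100000 nM in this assay, at which 2 of the 3 values shown sit).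

Compound 4 `Cc1cc(Cl)ccc1C(=O)Nc1ccc(Cl)c(-c2nnc3c(Cl)cccn23)c1` is the next variation: 4-chloro-2-methylphenyl in place of pyridin-3-yl on a carbonyl carbon. Within the data shown here, the only sized step that bears on such an exchange of the ring on the carbonyl carbon is the one from compound 1 to compound 2, which stayed within the scatter even at its floor. Since every ring tried so far at this carbon has left the assay at or near its limit, the step of a number no higher from compound 2 to compound 4 (the limit leaves the size open) is expected to be none beyond the scatter. The estimate for compound 4 is 100000 nM, within a range from 30000 nM to 300000 nM.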

Compound 4, half-maximal inhibitory concentration: > 100000 nM
Compound 4: only a limit was reported; the forecaster's own chance of this, stated with the estimate: 60%; the middle value lies on the limit itself.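

Compound 4 in this assay also gives only a limit, > 100000 nM, so a second ring of carbon only, this one 4-chloro-2-methylphenyl, ends up in the same place as the trifluoromethyl-bearing ring of compound 3. Among these compounds, the step from compound 2 to compound 4 cannot be read, as both ends are limits, and the one readable new step, an at least 1.2-fold higher number from compound 1 to compound 4 (0.10 log units; that floor lies within the scatter), gives only a floor, so compound 4 cannot be told apart from compound 1. With four different rings now tried on this carbonyl carbon, including pyridines and substituted phenyls, only compound 1 has a measured number, and even that number is not shown to lie beyond the scatter from the limit: the limit of > 100000 nM in this assay, at which 3 of the 4 values shown sit.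

Going by these compounds, it remains open whether a group of another kind on this carbonyl carbon, such as a longer alkyl chain or a ring carrying an amine or a carboxylic acid, would give a number clearly under the limit. On these data alone, how compound 2, compound 3 and compound 4 rank against one another also stays open, as their limits hide any differences among them.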